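The source may report more compounds than this note shows. Statements on the series, on what has been measured and on what is new or still open speak of the compounds shown alone.

Measured so far in a functional assay on HCT-116 cells (Homo sapiens) for cytotoxicity, read by MTT assay, with a stated time of 72 h; a lower number here means a stronger inhibitor, a higher number a weaker inhibitor:

compound 1 `CS(=O)(=O)Oc1c(C(=O)NCc2ccc(F)cc2)nc(Br)c2cccnc12`: > 20000 nM
compound 2 `CS(=O)(=O)NCCCN(c1nc(C(=O)NCc2ccc(F)cc2)c(O)c2ncccc12)S(C)(=O)=O`: 7000 nM
compound 3 `NCCCNc1c(C(=O)NCc2ccc(F)cc2)ncc2cccnc12`: > 10000 nM

Among the compounds with values here, compound 1 `CS(=O)(=O)Oc1c(C(=O)NCc2ccc(F)cc2)nc(Br)c2cccnc12` is not pinned to a number in this assay; its reading is a limit of the assay, (the limit of > 20000 nM in this assay, at which 1 of the 3 values shown sits), and compound 1 is the one value that sits at it. Compound 3 likewise returns only a limit in this assay, (the limit of > 10000 nM in this assay, at which 1 of the 3 values shown sits). Within the data shown here, compound 2 is the single compound of the three with a numeric reading, 7000 nM, so the series as a whole sits at the weak end of what this assay resolves, and no step between two measured compounds can be written down.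

The unmeasured compound 4 `Nc1cccc(Nc2c(C(=O)NCc3ccc(F)cc3)nc(Br)c3cccnc23)c1` keeps the shared core of compound 1, with the amide to the fluorobenzyl group and the bromo group in place, and changes one position: (3-aminophenyl)amino in place of (methylsulfonyl)oxy on an aromatic carbon. With compound 1 at a limit, any step from compound 1 to compound 4 can only be read as a move away from that limit or none at all; nothing among the three measured compounds supports a large gain, and compound 3, which also carries an amino-bearing chain on the core, sits at a limit as well.

Compound 4 is therefore expected to give roughly 15000 nM in this assay, with a plausible range from 3000 nM to 60000 nM. That estimate means a step from compound 1 to compound 4 of an at least 1.3-fold lower number from compound 1 to compound 4 (0.12 log units; that floor lies within the scatter), expected to be small, with a fair chance that the assay again reports only a limit.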

Compound 4, half-maximal inhibitory concentration: > 10000 nM
Compound 4: no number, only a limit; the forecaster's own chance of this, stated with the estimate: 50%; the middle value is on the limit's open side.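

Compound 4 returns only a limit in this assay, > 10000 nM. Within the data shown here, compound 1 is also a limit, > 20000 nM, and no step from compound 1 to compound 4 can be read. The compounds shown leave open whether (3-aminophenyl)amino in place of (methylsulfonyl)oxy on the shared core changes the reading at all.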